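A Chloro Step Repeated on Two Cores

The source may hold more compounds than are shown below. What is called first, only, known or untested is meant among the compounds shown, and "the series" means these compounds.

Three compounds were measured in a functional assay on the whole organism (strain albino) for inhibition, with Rattus norvegicus as the target, read by paw edema, with stated times of 30 min and 24 h, at a dose of 50 mg/kg by the oral route; on this read-out lower numbers stand for less inhibition and higher numbers for more inhibition at the one dose given (going by the name of the read-out):

Compound 1 `O=C(O)CCC(=O)/C=C/c1cn(-c2ccccc2)nc1-c1ccccc1` gives 8.33%.
Compound 2 `O=C(O)CCC(=O)/C=C/c1cn(-c2ccccc2)nc1-c1ccc(Cl)cc1` gives 2.27%.
Compound 3 `NC(=O)c1ccccc1NC(=O)c1cn(-c2ccccc2)nc1-c1ccccc1` gives -3.79%.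

Compound 2 differs from compound 1 by chloro in place of hydrogen on an aromatic carbon, and this gave a number 6.1 percentage points lower from compound 1 to compound 2 (within the scatter). Compound 3 carries a different core; how its core differs from that of compound 1 is not broken down here, and its value stands lowest of the three. Compound 4 `NC(=O)c1ccccc1NC(=O)c1cn(-c2ccccc2)nc1-c1ccc(Cl)cc1` differs from compound 3 by chloro in place of hydrogen on an aromatic carbon, the same change at the same place as before. Because the earlier step was a number 6.1 percentage points lower from compound 1 to compound 2 (within the scatter), compound 4 is expected to show a number 3.2 percentage points lower from compound 3 to compound 4 (within the scatter) in this assay. Compound 4 is therefore estimated at -7%, with a range from -20% to 8%, and this estimate rests on that single earlier step alone.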

Compound 4, a percentage reported as inhibition, in the whole organism at one dose (the size of the read-out at that dose, not a potency): 15.2%
For compound 4 the middle estimate is 22.2 percentage points below the measured one, and the stated range ends below it.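

In this assay, chloro in place of hydrogen on an aromatic carbon gave a number 19 percentage points higher from compound 3 to compound 4 (beyond the scatter). Set beside the earlier step, the same change does not carry over unchanged from one core to the other: the same change on two cores in this assay, a number 6.1 percentage points lower (within the scatter) from compound 1 to compound 2 and a number 19 percentage points higher (beyond the scatter) from compound 3 to compound 4, 25.1 percentage points apart, beyond the scatter of two such steps This shows that, in this series, the step seen on one core is a poor guide to the step on the other, but it rests on a single pair per core at one dose and does not show why the two cores part ways.

The compounds shown leave open how a different group at the same place, such as fluoro, methoxy or an amine, would behave on these two cores.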